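Trifluoromethyl for methoxy on the N-aryl ring

A few compounds are considered here, and "the series" means these few. Any claim that something is new, unique, unknown or untested is made for them only; others in the source may bear on it.

Compound 1 `COc1cccc(-n2cnc3cc(C(=O)N4CCCCC4)ccc32)c1` and compound 3 `COc1ccc(-n2cnc3cc(C(=O)N4CCCCC4)ccc32)cc1` share a core; compound 3 differs from compound 1 in that (4-methoxyphenyl in place of 3-methoxyphenyl on an aromatic nitrogen). In an assay on isolated protein for inhibition of 15-hydroxyprostaglandin dehydrogenase [NAD(+)] (Homo sapiens), read by fluorescence, with a stated time of 15 min (a lower number here means a stronger inhibitor, a higher number a weaker inhibitor), compound 1 gives 19 nM, and compound 3 gives 19 nM; the step of no change at the digits printed from compound 1 to compound 3 (within the scatter) shows the two level at the digits printed.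

Compound 2 `O=C(c1ccc2c(c1)ncn2-c1cccc(C(F)(F)F)c1)N1CCCCC1` carries a change relative to compound 1: trifluoromethyl in place of methoxy on an aromatic carbon. In this assay compound 2 gives 48 nM, and the step of a 2.5-fold higher number from compound 1 to compound 2 (0.40 log units; beyond the scatter) is modest but lies beyond the scatter.

Compound 4 `O=C(c1ccc2c(c1)ncn2-c1ccc(C(F)(F)F)cc1)N1CCCCC1` has not yet been measured in this assay. It differs from compound 3 in that (trifluoromethyl in place of methoxy on an aromatic carbon). This is the same kind of change as from compound 1 to compound 2, but the place is not identical: in compound 2 the trifluoromethyl sits meta to a large group, in compound 4 para to a large group. Among the compounds with values here, only one instance of this change has been measured, so the estimate rests on that single step.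

The step is expected to be about a 2.5-fold higher number from compound 3 to compound 4 (0.40 log units; beyond the scatter), because the corresponding change gave a 2.5-fold higher number from compound 1 to compound 2 (0.40 log units; beyond the scatter) and the core of compound 3 gives the same number as that of compound 1. Compound 4 is therefore estimated at 48 nM in this assay, with a likely range from 20 nM to 120 nM.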

Compound 4, half-maximal inhibitory concentration: 86 nM
Compound 4: middle estimate off by 1.8-fold (0.25 log units), on the low side; measured number inside the range.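

In this assay, trifluoromethyl in place of methoxy gives a 4.5-fold higher number from compound 3 to compound 4 (0.66 log units; beyond the scatter), so the change raises the number on both aryl arrangements tested and lowers it on neither. The two steps point the same way and cannot be told apart in size: the same change on two cores in this assay, a 2.5-fold higher number (0.40 log units; beyond the scatter) from compound 1 to compound 2 and a 4.5-fold higher number (0.66 log units; beyond the scatter) from compound 3 to compound 4, 1.8-fold (0.25 log units) apart, within the scatter of two such steps This supports carrying the change between these two closely related compounds as a modest loss, but two pairs fix neither a constant size for the step nor its behaviour on any other core, and they do not show which difference between the two groups drives it.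

On these data alone, all four compounds carry the same amide on the shared core and only methoxy or trifluoromethyl on the aryl ring, so whether the step survives a different amide, such as one built from an open-chain amine, remains open. Also open, as far as these compounds go, is where a nitrile, a chlorine or a carboxylic acid on that ring would fall relative to methoxy and trifluoromethyl, and whether such groups would keep the number as low as compound 3 does.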